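A few compounds are considered here, and "the series" means these few. Any claim that something is new, unique, unknown or untested is made for them only; others in the source may bear on it.

Three compounds of one shared core, differing in the group on an aromatic carbon, have been measured in an assay on CHO cells for antagonist activity at transient receptor potential cation channel subfamily V member 1 (Homo sapiens), read by FLIPR; on this read-out lower numbers stand for stronger inhibition and higher numbers for weaker inhibition. Compound 1 `CCCN(CCC)c1cc(C(F)(F)F)ccc1CNC(=O)C(C)c1ccc(NS(C)(=O)=O)c(F)c1` gives 0.3 nM, the lowest of the three numbers. Compound 2 `CC(C(=O)NCc1ccc(C(F)(F)F)cc1N1CCC(Cc2ccc(F)cc2)CC1)c1ccc(NS(C)(=O)=O)c(F)c1` gives 0.4 nM, which lies within the scatter of compound 1. Compound 3 `CC(C(=O)NCc1ccc(C(F)(F)F)cc1N1CCN(C2CCCCC2)CC1)c1ccc(NS(C)(=O)=O)c(F)c1` gives 13.8 nM, and the step of a 46-fold higher number from compound 1 to compound 3 (1.66 log units; beyond the scatter) is large and well beyond the scatter. Compound 4 `CC(C)COc1cc(C(F)(F)F)ccc1CNC(=O)C(C)c1ccc(NS(C)(=O)=O)c(F)c1` has not yet been measured. Its change from compound 1 is isobutoxy in place of dipropylamino on an aromatic carbon; like the step to compound 3 it removes the dipropylamino group, but here a short chain enters rather than a ring. Only the large step to compound 3 bears on this. A smaller loss is expected, with a 10-fold higher number from compound 1 to compound 4 (1.00 log units; beyond the scatter). Compound 4 is therefore estimated at 3 nM, ranging from 0.5 nM to 20 nM.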

Compound 4, inhibition constant: 0.8 nM
Compound 4: middle estimate off by 3.8-fold (0.57 log units), on the high side, and the stated range covers the measured number.
By their numbers in this assay, from the lowest: compounds 1, 2 and 4 (each within the scatter of the next, the first and the last beyond it); then compound 3.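

Replacing dipropylamino with isobutoxy on this aromatic carbon in this assay brings only a modest change (a 2.7-fold higher number from compound 1 to compound 4 (0.43 log units; beyond the scatter)), so a nitrogen attached at this position is not needed for a number close to that of compound 1. The large loss seen with compound 3 is therefore not shared by every replacement of dipropylamino, as the opposite step shows (a 17-fold lower number from compound 3 to compound 4 (1.24 log units; beyond the scatter)). No measurement here accounts for either step. As far as these compounds go, whether a methoxy group, a longer ether chain or an unsubstituted amine would hold the number at this position remains open.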